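From Carbamoyl to Carboxy on a Shared Core

The compounds below may be only part of what the source reports. "The series", "measured", "known", "first", "only" and "open" are said of these compounds alone.

Of the compounds shown here, three sharing one core have been tested in a functional assay on HeLa cells (Homo sapiens) for cytotoxicity, read by MTT assay, with a stated time of 48 h (a lower number here means a stronger inhibitor, a higher number a weaker inhibitor), and their numbers differ clearly. Compound 1 `Cc1n[nH]c2c1C(c1ccc(N(C)C)cc1)C(C(=O)NN)=C(N)N2` gives 51300 nM and compound 2 `Cc1n[nH]c2c1C(c1ccc(N(C)C)cc1)C(C(=O)N/N=C/c1ccc(Cl)cc1)=C(N)N2` gives 31700 nM while compound 3 `Cc1n[nH]c2c1C(c1ccc(N(C)C)cc1)C(C(N)=O)=C(N)N2` gives 5770 nM as the lowest number of the three. Compound 4 `Cc1n[nH]c2c1C(c1ccc(N(C)C)cc1)C(C(=O)O)=C(N)N2` changes carbamoyl to carboxy: hydroxy in place of amino on a carbonyl carbon with hydroxy in place of amino on a carbonyl carbon. Among the compounds with values here, no measured step makes this exact change. The closest guides are changes on the amide-type nitrogen, where an 8.9-fold lower number from compound 1 to compound 3 (0.95 log units; beyond the scatter) and a 5.5-fold lower number from compound 2 to compound 3 (0.74 log units; beyond the scatter) are both modest and both end at the lowest number. Losing the amino group of compound 3 is therefore expected to move the number upward, though less far: a 2.9-fold higher number from compound 3 to compound 4 (0.47 log units; beyond the scatter) is the estimated step. Compound 4 is estimated at 17000 nM with 5000 nM and 60000 nM as the expected lower and upper ends.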

Compound 4, half-maximal inhibitory concentration: 33600 nM
Compound 4: the middle estimate sits 2.0-fold (0.30 log units) below what was measured; low and high end bracket the measured number.
By their numbers in this assay, from the lowest: compound 3; then compounds 2, 4 and 1 (each within the scatter of the next).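

In this assay hydroxy in place of amino on this carbonyl carbon brings a 5.8-fold higher number from compound 3 to compound 4 (0.77 log units; beyond the scatter) and so sets the plain carbamoyl apart from the carboxy group. Against the two longer groups, carboxy shows no clear gap: a 1.1-fold higher number from compound 2 to compound 4 (0.03 log units; within the scatter) and a 1.5-fold lower number from compound 1 to compound 4 (0.18 log units; within the scatter) both lie within the scatter. From the compounds shown here alone, whether a methyl ester or an N-methyl amide on this carbonyl carbon would stay close to compound 3 or to compound 4 remains open. No measured evidence here speaks to the cause of this gap.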